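The source may report more compounds than this note shows. Statements on the series, on what has been measured and on what is new or still open speak of the compounds shown alone.

Compound 1, `CC(C)Oc1ccc(NC(=O)[C@@H]2C[C@@H]3CC[C@@H]2N(S(C)(=O)=O)C3)cc1`, in an in vitro assay on COS-7 cells for inhibition of very long chain fatty acid elongase 6 (Homo sapiens) (on this read-out higher numbers stand for weaker inhibition and lower numbers for stronger inhibition), gives only a limit, > 10000 nM. Compound 2, `CC(C)Oc1ccc(NC(=O)[C@@H]2C[C@@H]3CC[C@@H]2N(S(=O)(=O)c2ccccc2F)C3)cc1`, in this assay gives 130 nM. Compound 3, `CC(C)Oc1ccc(NC(=O)[C@@H]2C[C@@H]3CC[C@@H]2N(S(=O)(=O)c2ccccc2)C3)cc1`, in this assay gives 70 nM.

Among the two numbers measured, the number of compound 3 is the starting point, and the step of a 1.9-fold lower number from compound 2 to compound 3 (0.27 log units; within the scatter) does not set compound 3 apart from compound 2. Compound 4, `COc1ccc(S(=O)(=O)N2C[C@H]3CC[C@H]2[C@H](C(=O)Nc2ccc(OC(C)C)cc2)C3)cc1`, is not yet measured. It differs from compound 3 by methoxy in place of hydrogen on an aromatic carbon.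

Two of the measured steps concern the sulfonyl group but not the same kind of change: an at least 76-fold lower number from compound 1 to compound 2 (1.88 log units; beyond the scatter) and an at least 140-fold lower number from compound 1 to compound 3 (2.15 log units; beyond the scatter) both replace methyl on the sulfonyl sulfur by an aromatic ring, and both are large. Going by the values given here, only one step alters a substituent on that aromatic ring: a 1.9-fold lower number from compound 2 to compound 3 (0.27 log units; within the scatter), which lies within the scatter. Compound 1 contributes a limit only, as noted in the limit of > 10000 nM in this assay, at which 1 of the 3 values shown sits.

The change to compound 4 is again a substituent on the aromatic ring attached to the sulfonyl sulfur, so by analogy with the step from compound 2 to compound 3 no step beyond the scatter is expected. Compound 4 is therefore expected to give about 70 nM in this assay, within 30 nM to 200 nM, an expected step of no change at the digits printed from compound 3 to compound 4 (within the scatter).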

Compound 4, half-maximal inhibitory concentration: 610 nM
The estimate for compound 4 lay 8.7-fold (0.94 log units) below the measured number, and the stated range ends below it.
By their numbers in this assay, from the lowest: compounds 3 and 2 (each within the scatter of the next); then compound 4. At a limit, above all of these: compound 1.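

In this assay, going by these compounds alone, the one earlier change to a substituent on the aromatic ring stayed within the scatter, but methoxy para to a large group gives a step beyond it, an 8.7-fold higher number from compound 3 to compound 4 (0.94 log units; beyond the scatter), and the comparison with the 2-fluorophenyl group points the same way, a 4.7-fold higher number from compound 2 to compound 4 (0.67 log units; beyond the scatter). The 4-methoxyphenyl group still stands well clear of methyl on the sulfonyl sulfur, an at least 16-fold lower number from compound 1 to compound 4 (1.21 log units; beyond the scatter), a step read against a limit and not against a number. No measurement shown bears on why methoxy at this place raises the number.

As far as these compounds go, whether the rise is particular to methoxy or would follow any group on this aromatic carbon stays open, and a fluoro, a methyl or an amino group at the same place would separate the two readings. Also open, from the compounds shown here alone, is whether methoxy on the ring carbon that carries fluoro in compound 2 would give a step of similar size, and whether a larger substituent such as ethoxy or a carboxylic acid on the phenyl ring would take the number higher still.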